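Ethoxy in place of methoxy on the aryl amide series

The source may report more compounds than this note shows. Statements on the series, on what has been measured and on what is new or still open speak of the compounds shown alone.

Of the compounds shown here, three of the shared core have been measured in a functional assay on MG-63 cells (Homo sapiens) for inhibition, read by CCK-8 assay, with a stated time of 72 h, tested at 1 uM; on this read-out higher numbers stand for more inhibition at the one concentration tested (going by the name of the read-out) and lower numbers for less inhibition. Compound 1 `COc1ccccc1N1C(=O)C(C)SC1c1cccc(C(=O)NCCCCc2ccccc2)c1` gives 94%, the largest of the three numbers. Compound 2 `O=C(NCCCCc1ccccc1)c1cccc(C2SCC(=O)N2c2cccc(F)c2)c1` gives 92%, a number within the scatter of compound 1. Compound 3 `O=C(NCCCCc1ccccc1)c1cccc(C2OCC(=O)N2c2cccc(F)c2)c1` gives 66%, well beyond the scatter below compound 1. Going by the values given here, no single-point step between measured compounds is available. Compound 4 `CCOc1ccccc1N1C(=O)C(C)SC1c1cccc(C(=O)NCCCCc2ccccc2)c1` differs from compound 1 by methyl in place of hydrogen on a saturated chain carbon bound to an oxygen on an aromatic ring. Nothing in the measured set speaks to this change, and both measured thiazolidinone compounds sit near the top of the read-out, so the step of a number 4 percentage points lower from compound 1 to compound 4 (within the scatter) is expected to be small, no larger than the scatter, if anything slightly downward. Compound 4 is estimated at 90%, within 75% to 98% in this assay .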

Compound 4, a percentage reported as inhibition, at one concentration (the size of the read-out at that concentration, not a potency): 92%
Estimate against measurement, compound 4: 2 percentage points below; low and high end bracket the measured number.
By their numbers in this assay, from the lowest: compound 3; then compounds 2, 4 and 1 (each within the scatter of the next).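

In this assay, going by these compounds alone, the change from methoxy to ethoxy gives a number 2 percentage points lower from compound 1 to compound 4 (within the scatter), the first direct reading at this position: the added methyl leaves the number inside the scatter. With both compounds near the top of the read-out, a single concentration shows only that this position accepts the 2-ethoxyphenyl group, not whether potency is kept. No supporting data bear on the reason for this result.

Open, going by these compounds, is whether a longer chain on that oxygen, such as propyl or benzyl, holds the number. Also open, on these data alone, is whether a terminal amine or carboxylic acid on the chain does the same.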